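Chloro to hydrogen swap carried from one core to another

The compounds below may be only part of what the source reports. "The series", "measured", "known", "first", "only" and "open" are said of these compounds alone.

Compound 1 `O=C1C2=C(C(=O)c3ncccc31)C1(CS2)NC(=O)N(c2ccc(Cl)cc2)C1=O` and compound 2 `O=C1C2=C(C(=O)c3ncccc31)C1(CS2)NC(=O)N(c2ccccc2)C1=O` share one core and differ only on the aryl ring. In a functional assay on HT-29 cells (Homo sapiens) for antiproliferative activity, read by MTT assay, with a stated time of 96 h (a higher number here means a weaker inhibitor, a lower number a stronger inhibitor), compound 1 gives 2 nM and compound 2 gives 2 nM. The change between them is hydrogen in place of chloro on an aromatic carbon, and the measured outcome is no change at the digits printed from compound 1 to compound 2 (within the scatter).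

Compound 3 `O=C1NN(c2ccc(Cl)cc2)C(=O)C2(CSC3=C2C(=O)c2ncccc2C3=O)N1` is built on a second core; how its core differs from that of compound 1 is not broken down here. In this assay compound 3 gives 220 nM, the highest of the three measured numbers, with compound 1 as its nearest measured neighbour.

Compound 4 `O=C1NN(c2ccccc2)C(=O)C2(CSC3=C2C(=O)c2ncccc2C3=O)N1` has not been measured. It differs from compound 3 by hydrogen in place of chloro on an aromatic carbon, the same change at the same place as that separating compound 1 from compound 2. Within the data shown here, the only precedent for this change is the step from compound 1 to compound 2, which stayed within the scatter. On that basis the expected step is no change at the digits printed from compound 3 to compound 4 (within the scatter), to be set beside no change at the digits printed from compound 1 to compound 2 (within the scatter). This expectation rests on a single pair measured on the other core, so the bounds are kept wide. Compound 4 is estimated at 220 nM in this assay, with a range from 90 nM to 550 nM.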

Compound 4, half-maximal inhibitory concentration: 550 nM
The estimate for compound 4 lay 2.5-fold (0.40 log units) below the measured number, and the stated range covers the measured number.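

In this assay, replacing 4-chlorophenyl with phenyl on the second core gives a 2.5-fold higher number from compound 3 to compound 4 (0.40 log units; beyond the scatter) and, set beside the same change on the first core, the two steps do not separate: the same change on two cores in this assay, no change at the digits printed (within the scatter) from compound 1 to compound 2 and a 2.5-fold higher number (0.40 log units; beyond the scatter) from compound 3 to compound 4, 2.5-fold (0.40 log units) apart, within the scatter of two such steps

Among these compounds, the change therefore carries from one core to the other as far as these two pairs can tell, although only the step on the second core lies beyond the scatter when read alone. This does not establish that the change has the same size on both cores, nor that the cores respond differently, and with a single pair on each core it gives no general rule for the series. It also gives no reason for the step, and nothing shown here separates any effect of the chloro group from the scatter of the two steps taken together.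

The compounds shown leave open how other groups on the same aromatic carbon would behave on either core, such as a methoxy group, an amine or a carboxylic acid. They also leave open whether a longer chain in place of the aryl ring would follow the same course on both cores.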